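The compounds below may be only part of what the source reports. "The series", "measured", "known", "first", "only" and "open" are said of these compounds alone.

Compound 2 (`O=C(Nc1ccc(S(=O)(=O)Nc2ncccn2)cc1)c1ccc(Cl)cc1Cl`) is the starting point of this step, yet it carries no number: in a functional assay on HEK293 cells for agonist activity at probable G-protein coupled receptor 27 (Homo sapiens), read by a luciferase reporter and beta-arrestin recruitment, with a stated time of 10 min (a higher number here means a larger maximal response, a lower number a smaller maximal response), compound 2 is recorded only as "not determined" (no result reported), so there is no value to place it against. Among the compounds with values here, the one measured member of this series is compound 1 (`O=C(Nc1ccc(S(=O)(=O)Nc2cccc(Cl)c2)cc1)c1ccc(Cl)cc1Cl`), built on the same core, for which this assay gives compound 1 a maximal response of 40%. That single value is the only anchor available.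

Compound 3 (`Cc1ccccc1NS(=O)(=O)c1ccc(NC(=O)c2ccc(Cl)cc2Cl)cc1`) is the new member to be tested. The change from compound 2 to compound 3 is 2-methylphenyl in place of pyrimidin-2-yl on a sulfonamide nitrogen. Compound 2 has no measured response. Within the data shown here, no step can be computed, and nothing in the data shows whether the change raises or lowers the maximal response. The expectation can rest only on compound 1, which also carries a carbon-only aromatic ring on the sulfonamide nitrogen and reaches a response of 40%. On that basis the maximal response of compound 3 is estimated at 40%, with a likely range from 20% to 65%, a partial response close to that of compound 1 rather than a full one.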

Compound 3, largest response reached (Emax), in percent of the reference or control that the assay uses: 32%
For compound 3 the middle estimate is 8 percentage points above the measured one, and the stated range covers the measured number.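

In this assay, placing 2-methylphenyl where compound 1 carries 3-chlorophenyl on the sulfonamide nitrogen gives a number 8 percentage points lower from compound 1 to compound 3 (within the scatter), so this exchange of one carbon-only aromatic ring for another leaves the maximal response unchanged within the scatter. The series now has two measured members at this position rather than one, and with compound 3 at 32% the response of compound 1 no longer stands alone, although both compounds remain the only anchors for this nitrogen substituent. The data shown offer no measurement that explains the response of either compound.

From the compounds shown here alone, the step from compound 2 to compound 3 cannot be read, as compound 2 has no number, so whether pyrimidin-2-yl on the sulfonamide nitrogen gives a response different from that of these carbon-only rings remains open. Also open, going by these compounds, is how the maximal response would change with a non-aromatic group at this position, such as cyclohexyl or a short alkyl chain, or with an amine or a carboxylic acid on the aromatic ring.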